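Double-bond geometry: from compound 2 to compound 3

This account rests on a few compounds, and the source may have more. Where it says the series, first, only, none or still open, it means among the compounds named here.

In a functional assay on MCF7 cells (Homo sapiens) for cytotoxicity, read by MTT assay, with a stated time of 48 h (a lower number here means a stronger inhibitor, a higher number a weaker inhibitor), compound 1 (`CCOC(=O)C1=C(C)NC(=S)NC1c1cccc(OCCCCOc2cccc(C3NC(=S)NC(C)=C3C(=O)OCC)c2)c1`) gives 186 ug/mL and compound 2 (`CCOC(=O)C1=C(C)NC(=S)NC1c1ccc(OC/C=C\COc2ccc(C3NC(=S)NC(C)=C3C(=O)OCC)cc2OC)c(OC)c1`) gives 84 ug/mL as the lower of the two numbers, a gap beyond the scatter. Compound 3 (`CCOC(=O)C1=C(C)NC(=S)NC1c1ccc(OC/C=C/COc2ccc(C3NC(=S)NC(C)=C3C(=O)OCC)cc2OC)c(OC)c1`) has not yet been measured. Its difference from compound 2 reads (the two compounds have the same atoms and bonds; at least one stereo element is drawn with a configuration in one of them and without one in the other: 1 of 3 stereo elements differ; a double bond is drawn Z in compound 2 and E in compound 3), so a double bond is drawn Z in compound 2 and E in compound 3, while atoms and bonds stay the same. Within the data shown here, no measured pair shows what such a change does. The estimate therefore stays close to compound 2 at 84 ug/mL and leans only slightly towards the higher number of compound 1 at 186 ug/mL in the same read-out. The expected 1.1-fold higher number from compound 2 to compound 3 (0.05 log units; within the scatter) in this assay is none beyond the scatter, with a slightly weaker result the likelier direction. The estimate for compound 3 is 95 ug/mL as expected value, within an expected range of 45 ug/mL to 190 ug/mL in this series.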

Compound 3, half-maximal inhibitory concentration: 35 ug/mL
Compound 3: middle estimate off by 2.7-fold (0.43 log units), on the high side, outside the stated range (below it).
By their numbers in this assay, from the lowest: compound 3; then compound 2; then compound 1.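

In this assay, among these compounds, the double bond is the first place where a single change can be read on its own: a 2.4-fold lower number from compound 2 to compound 3 (0.38 log units; beyond the scatter). Atoms and bonds stay the same, so a change in drawn geometry alone, Z in compound 2 and E in compound 3, goes with a step beyond the scatter, and the E form carries the lower number. This rests on one pair, and one caution applies to tying the step to that double bond alone: the fact that one of compounds 2 and 3 is drawn with a defined configuration and the other without, at the place where they differ

On these data alone, whether the lower number with the E double bond holds for a longer chain, or with a triple bond in its place, stays open. Also open, as far as these compounds go, is how this pair would respond to a carboxylic acid in place of the ethyl ester on the shared core.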